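Extending the ethyl chain at the assay limit

This account rests on a few compounds, and the source may have more. Where it says the series, first, only, none or still open, it means among the compounds named here.

In an ADME assay on MCF7-DOX cells (Homo sapiens) for cytotoxicity, read by MTT assay, with a stated time of 48 h (a lower number here means a stronger inhibitor, a higher number a weaker inhibitor), compound 1 (`COc1cc(O)c(C(=O)/C=C/c2cccc(N3CCNCC3)c2)c(OC)c1`) gives 99200 nM. Compound 2 (`COc1cc(OC)c(C(=O)/C=C/c2cccc(N3CCNCC3)c2)c(O)c1CC=C(C)C`) gives 99900 nM. Compound 3 (`CCc1c(OC)cc(OC)c(C(=O)/C=C/c2cccc(N3CCNCC3)c2)c1O`) gives > 100000 nM, which is a limit and not a number.

Compound 4 (`CCCCc1c(OC)cc(OC)c(C(=O)/C=C/c2cccc(N3CCNCC3)c2)c1O`) differs from compound 3 by ethyl in place of hydrogen on a saturated chain carbon, two bonds along the chain from an aromatic carbon, that is, ethyl to butyl. The closest evidence is the 3-methylbut-2-en-1-yl step, a 1.0-fold higher number from compound 1 to compound 2 (0.00 log units; within the scatter). On these data alone, the steps of a number no lower from compound 1 to compound 3 (the limit leaves the size open) and a number no lower from compound 2 to compound 3 (the limit leaves the size open) give direction only, since their size stays open. No change beyond the scatter is therefore expected, and compound 4 may also report only a limit. The expected step is a number no higher from compound 3 to compound 4 (the limit leaves the size open). For compound 4 the estimate is 100000 nM, with an expected range of 60000 nM to 170000 nM.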

Compound 4, half-maximal inhibitory concentration: > 100000 nM
Compound 4 was reported as a limit; the forecaster's own chance of this, stated with the estimate: 60%; the middle value lies on the limit itself.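

Compound 4 is also a limit in this assay and not a number, so going from ethyl to butyl on this chain brings no reading back inside the assay range. Against the compounds with a number, the chain gives a number no lower from compound 1 to compound 4 (the limit leaves the size open) and also a number no lower from compound 2 to compound 4 (the limit leaves the size open) with direction only. The step between the two limit compounds cannot be read, because both sit at the ceiling: the limit of > 100000 nM in this assay, at which 2 of the 4 values shown sit.

On these data alone, whether any group at this position reads below the limit stays open. A terminal amine or carboxylic acid on the chain, or a longer octyl chain, would test this.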